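The compounds below may be only part of what the source reports. "The series", "measured", "known", "first", "only" and "open" are said of these compounds alone.

Compound 1 `NS(=O)(=O)Oc1ccc2c(c1)CN(C(=O)c1cccc(N(Cc3ccccc3)Cc3ccco3)c1)CC2` was examined in an assay on HEK293 cells for inhibition of Steryl-sulfatase (Homo sapiens), tested at 0.1 uM (on this read-out lower numbers stand for a weaker effect and higher numbers for a stronger effect at the one concentration tested), alongside compound 2 `CCN(Cc1ccccn1)c1ccc(C(=O)N2CCc3ccc(OS(N)(=O)=O)cc3C2)cc1`. In this assay compound 1 gives 27.5%, the lower of the two numbers recorded so far. Compound 2 gives 42.5% in this assay, a result that lies beyond the scatter of the reading for compound 1. Compound 3 `NS(=O)(=O)Oc1ccc2c(c1)CN(C(=O)c1cccc(N(CCCO)Cc3ccccc3)c1)CC2` has not yet been measured in this assay; it keeps the core of compound 1 and differs from it in one place: 2-hydroxyethyl in place of furan-2-yl on a saturated chain carbon bound to a nitrogen on an aromatic ring. Among the measured compounds shown here, no step between measured compounds speaks to this particular change, so any expectation rests on compound 1 alone. The step from compound 1 to compound 3 is expected to be small, in either direction or none beyond the scatter, a number 2.5 percentage points lower from compound 1 to compound 3 (within the scatter). Compound 3 is therefore estimated to give 25% in this assay, with a range from 5% to 50%.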

Compound 3, a percentage reported as inhibition, at one concentration (the size of the read-out at that concentration, not a potency): 25.8%
Compound 3: middle estimate off by 0.8 percentage points, on the low side; the measured number falls inside the stated range.
By their numbers in this assay, from the lowest: compounds 3 and 1 (each within the scatter of the next); then compound 2.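

In this assay, 2-hydroxyethyl in place of furan-2-yl on a saturated chain carbon bound to a nitrogen on an aromatic ring gives a number 1.7 percentage points lower from compound 1 to compound 3 (within the scatter). At this position, then, the five-membered aromatic ring can give way to an open chain carrying a hydrogen-bond donor without a change that stands out from the scatter. At the one concentration tested, the read-out does not separate (furan-2-yl)methyl from 3-hydroxypropyl. Nothing available explains this outcome.

The compounds shown leave open whether a chain ending in an amine or a carboxylic acid, or a longer chain, would give a number beyond the scatter of these two. They also leave open whether the benzyl group on the same nitrogen matters to the read-out.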